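The source may hold more compounds than are shown below. What is called first, only, known or untested is meant among the compounds shown, and "the series" means these compounds.

Measured compounds:
- compound 1 `C=CCOc1ccc2c(NCCCN(C)C)ccnc2c1`: 3120 nM
- compound 2 `CCOc1ccc2c(NCCCN(C)C)ccnc2c1`: 3830 nM
- compound 3 `Clc1ccnc2cc(OCc3ccccc3)ccc12`: 2720 nM

All three numbers come from a functional assay on NCI-H1650 cells (Homo sapiens) for cytotoxicity, read by MTT assay, with a stated time of 48 h; on this read-out higher numbers stand for weaker inhibition and lower numbers for stronger inhibition. Compound 1 sits in the middle of the three, and its gaps to compound 2 and to compound 3 are both within the usual scatter, so none of the three can be told apart from the others on these data.

Going by the values given here, the one step between compounds that differ in a single place, a 1.2-fold higher number from compound 1 to compound 2 (0.09 log units; within the scatter), concerns the chain on the ring oxygen and leaves the amine-bearing chain untouched.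

Compound 4 `C=CCOc1ccc2c(NCCN(C)C)ccnc2c1` is not yet measured. It differs from compound 1 in dimethylamino in place of (dimethylamino)methyl on a saturated chain carbon, two bonds along the chain from a nitrogen on an aromatic ring. Among the compounds with values here, no measured pair shows a change of this kind; the only step on hand, from compound 1 to compound 2, alters a different part of the molecule and stays within the scatter. Within the data shown here, there is therefore no precedent for the shortening of the amine chain, and no direction can be read from the measured numbers. The working expectation is a step from compound 1 to compound 4 of a 1.1-fold higher number from compound 1 to compound 4 (0.05 log units; within the scatter), that is, no change beyond the scatter, with a wide margin for the lack of precedent. Compound 4 is estimated at 3500 nM in this assay, within a range of 1200 nM to 10000 nM.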

Compound 4, half-maximal inhibitory concentration: 930 nM
The estimate for compound 4 lay 3.8-fold (0.58 log units) above the measured number, outside the stated range (below it).
By their numbers in this assay, from the lowest: compound 4; then compounds 3, 1 and 2 (each within the scatter of the next).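

Shortening the amine-bearing chain, with (2-(dimethylamino)ethyl)amino in place of (3-(dimethylamino)propyl)amino, gives a 3.4-fold lower number from compound 1 to compound 4 (0.53 log units; beyond the scatter) in this assay and is the first single change in the series to go beyond the scatter. The earlier change on the chain at the ring oxygen, a 1.2-fold higher number from compound 1 to compound 2 (0.09 log units; within the scatter), stayed within the scatter, so the amine-bearing chain is the only place shown so far where a single change separates two compounds, and this rests on one modest step from one pair. Nothing on hand accounts for the lower number with the shorter chain.

Going by these compounds, it remains open whether the same shortening gives a step of similar direction and size on the ether chain of compound 2, since one pair cannot show whether the effect carries over to other ether chains. Also open, on these data alone, is how the number responds to a longer chain such as 4-(dimethylamino)butyl, or to a diethylamino or pyrrolidine group in place of dimethylamino at the end of the 2-(dimethylamino)ethyl chain.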